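The source may hold more compounds than are shown below. What is called first, only, known or untested is meant among the compounds shown, and "the series" means these compounds.

Among the measured compounds shown here, in a functional assay on MCF7 cells (Homo sapiens) for antiproliferative activity, read by MTT assay, with a stated time of 48 h (a higher number here means a weaker inhibitor, a lower number a stronger inhibitor), compound 1 (`O=C(CN1CCCC1)Nc1ccc2ncnc(Nc3ccc(Cl)cc3)c2c1`) gives 16000 nM, the only actual number so far. Compound 2 (`O=C(CN1CCCCC1)Nc1ccc2ncnc(Nc3ccc(Cl)cc3)c2c1`) reaches only a limit of the assay, > 100000 nM. Compound 3 (`O=C(CN1CCCC1)Nc1ccc2ncnc(Nc3ccc(Cl)c(C(F)(F)F)c3)c2c1`) also reaches only a limit, > 100000 nM.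

Compound 4 (`O=C(CN1CCCC1)Nc1ccc2ncnc(Nc3ccc(OCc4ccccc4)cc3)c2c1`) has benzyloxy in place of chloro on an aromatic carbon. The nearest guide is an at least 6.2-fold higher number from compound 1 to compound 3 (0.79 log units; beyond the scatter), with trifluoromethyl in place of hydrogen on an aromatic carbon. Less direct is an at least 6.2-fold higher number from compound 1 to compound 2 (0.79 log units; beyond the scatter), with piperidin-1-yl in place of pyrrolidin-1-yl. Neither change replaces chloro, so the size remains uncertain, but a move towards a higher number is expected in this assay. The expected change is a 2.5-fold higher number from compound 1 to compound 4 (0.40 log units; beyond the scatter). For compound 4 the estimate is 40000 nM, with an expected range of 8000 nM to 100000 nM.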

Compound 4, half-maximal inhibitory concentration: > 100000 nM
Compound 4 gave a limit, no number (the forecaster's own chance of this, stated with the estimate: 40%); middle value at least 2.5-fold (0.39 log units) away from the limit.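

In this assay, compound 3 kept the chloro, whereas compound 4 replaces it, and benzyloxy at this position gives an at least 6.2-fold higher number from compound 1 to compound 4 (0.79 log units; beyond the scatter). Changes on the chloro-bearing ring and on the chain carbon have now each moved away from compound 1, so compound 1 alone retains a measurable value here. The result for compound 4 is a limit and not a number, so its step sets only a minimum size: the limit of > 100000 nM in this assay, at which 3 of the 4 values shown sit.

On these data alone, whether fluoro, methoxy or hydrogen in place of chloro would retain or improve on the value of compound 1 stays open. So does whether an amine at this position would behave like benzyloxy.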